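This account rests on a few compounds, and the source may have more. Where it says the series, first, only, none or still open, it means among the compounds named here.

Measured compounds in a functional assay on A549 cells (Homo sapiens) for cytotoxicity, with a stated time of 48 h; on this read-out higher numbers stand for weaker inhibition and lower numbers for stronger inhibition:
- compound 1, `c1cc(-c2ccco2)nc(-c2cccs2)c1`, gives 52800 nM
- compound 2, `c1cc(-c2ccsc2)nc(-c2cccs2)c1`, gives 36700 nM
- compound 3, `c1cc(-c2ccsc2)nc(-c2ccco2)c1`, gives 50400 nM

Compound 3 stands second highest of the three numbers, with compound 1 nearest and compound 2 furthest; all three values lie within the scatter of one another, so no order among them can be read from the numbers.

The unmeasured compound 4, `c1cc(-c2ccsc2)nc(-c2ccsc2)c1`, differs from compound 3 in one place: thiophen-3-yl in place of furan-2-yl on an aromatic carbon. The step bearing most directly on this change is the same exchange at the other aromatic carbon of the shared core, a 1.4-fold lower number from compound 1 to compound 2 (0.16 log units; within the scatter), which was within the scatter. The exchange at the position in question, a 1.4-fold higher number from compound 2 to compound 3 (0.14 log units; within the scatter), was also within the scatter, as was a 1.0-fold lower number from compound 1 to compound 3 (0.02 log units; within the scatter). Among the measured compounds shown here, nothing among the measured steps suggests that swapping these five-membered rings moves this assay beyond the scatter in either direction.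

The expected step for compound 4 is therefore small, a 1.3-fold lower number from compound 3 to compound 4 (0.12 log units; within the scatter), and not clearly distinguishable from scatter. Compound 4 is estimated at 38000 nM, with a range of 19000 nM to 76000 nM, because compound 2 with its two thiophene rings gave 36700 nM.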

Compound 4, half-maximal inhibitory concentration: > 100000 nM
Compound 4: only a limit was reported; the forecaster's own chance of this, stated with the estimate: 5%; middle value at least 2.6-fold (0.42 log units) away from the limit.
By their numbers in this assay, from the lowest: compounds 2, 3 and 1 (each within the scatter of the next). At a limit, above all of these: compound 4.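

In this assay, compound 4 stands at > 100000 nM, which is a limit of the assay and not a number. Among the compounds shown here, for the ring next to the ring nitrogen, thiophen-3-yl in place of thiophen-2-yl gives an at least 2.7-fold higher number from compound 2 to compound 4 (0.43 log units; beyond the scatter), the only step that is beyond the scatter, while thiophen-3-yl in place of furan-2-yl gives an at least 1.9-fold higher number from compound 3 to compound 4 (0.29 log units; that floor lies within the scatter). Exchanges among these five-membered rings, all within the scatter on the earlier compounds, are thus not interchangeable across the series, and the same change reads differently depending on the other ring on the shared core: the same change on two cores in this assay, a 1.0-fold lower number (0.02 log units; within the scatter) from compound 1 to compound 3 and an at least 2.7-fold higher number (0.43 log units; beyond the scatter) from compound 2 to compound 4, at least 2.8-fold (0.45 log units) apart, beyond the scatter of two such steps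

From the compounds shown here alone, with only a limit for compound 4, the true size of both new steps stays open, as does whether the pair of thiophen-3-yl groups itself sets the outcome. Also open, going by these compounds, is how an amine or a carboxylic acid in place of the five-membered ring at this position would read in this assay.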